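Aryl substituent swap on the shared core, antiproliferative read

This account rests on a few compounds, and the source may have more. Where it says the series, first, only, none or still open, it means among the compounds named here.

Measured in a functional assay on A2780 cells (Homo sapiens) for antiproliferative activity, read by MTT assay, with a stated time of 3 days; a higher number here means a weaker inhibitor, a lower number a stronger inhibitor:
compound 1 `CCCCOC1(c2ccc(Br)cc2)SC=C(C)n2c1noc2=O` gives 82000 nM
compound 2 `CC1=CSC(O)(c2cccc(C(F)(F)F)c2)c2noc(=O)n21` gives 60000 nM
compound 3 `CC/C=C\COC1(c2ccc(Cl)cc2)SC=C(C)n2c1noc2=O` gives 55000 nM

In this assay the three numbers sit close together: compound 2 lies within the scatter of compound 3, its nearest, and of compound 1, its furthest, so no ranking among the three can be read from them. Compound 4 `CC1=CSC(O)(c2cccc(Cl)c2)c2noc(=O)n21` differs from compound 2 by chloro in place of trifluoromethyl on an aromatic carbon. Among the compounds with values here, no measured pair in the set shares this change, so nothing in the data fixes its size or direction; with all three measured numbers within the scatter of one another, the expectation is a step no larger than the scatter, in either direction. The step expected is no change at the digits printed from compound 2 to compound 4 (within the scatter). Compound 4 is accordingly estimated at 60000 nM, with a range from 25000 nM to 150000 nM.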

Compound 4, half-maximal inhibitory concentration: > 100000 nM
Compound 4: only a limit was reported (the forecaster's own chance of this, stated with the estimate: 15%); middle value at least 1.6-fold (0.22 log units) away from the limit.
By their numbers in this assay, from the lowest: compounds 3, 2 and 1 (each within the scatter of the next). At a limit, above all of these: compound 4.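

In this assay compound 4 gives > 100000 nM, which is a limit of the assay and not a number. Chloro in place of trifluoromethyl on an aromatic carbon, meta to a large group, provides the only single-place step in the series: an at least 1.6-fold higher number from compound 2 to compound 4 (0.22 log units; that floor lies within the scatter). The true size of this step remains unfixed, with only its floor known, and that floor rests on a limit: the limit of > 100000 nM in this assay, at which 1 of the 4 values shown sits.

Going by these compounds, whether the change reaches beyond the scatter remains open. So does how an amine or a carboxylic acid would read at this aromatic carbon.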